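The source may report more compounds than this note shows. Statements on the series, on what has been measured and on what is new or still open speak of the compounds shown alone.

Measured so far in an assay on isolated protein for inhibition of Gonadotropin-releasing hormone receptor (Homo sapiens); a higher number here means a weaker inhibitor, a lower number a stronger inhibitor:
- compound 1, `CC(C)n1c(SCc2ccccc2Cl)nc2cc(NC(=O)C3CC3)ccc21`: 6300 nM
- compound 2, `COc1ccc(C#N)cc1CSc1nc2cc(NC(=O)C3CC3)ccc2n1C(C)C`: 570 nM
- compound 3, `CCCn1c(SCc2cc([N+](=O)[O-])ccc2OC)nc2cc(NC(=O)NC(C)(C)C)ccc21`: 18 nM

Compound 3 gives the lowest number of the three; compound 2 gives 570 nM and compound 1 gives 6300 nM, both higher, each by a margin beyond the scatter. Among the measured compounds shown here, the one step with a single change, an 11-fold lower number from compound 1 to compound 2 (1.04 log units; beyond the scatter), concerns the group on the sulfur-bound chain carbon, not the group on the aromatic nitrogen.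

Compound 4, `COc1ccc([N+](=O)[O-])cc1CSc1nc2cc(NC(=O)NC(C)(C)C)ccc2n1Cc1ccccc1`, differs from compound 3 in one place: phenyl in place of ethyl on a saturated chain carbon bound to an aromatic nitrogen. For the measured compounds named here, no measured step touches this position; compounds 1 and 2 differ from compound 3 in more than one place, so their values give no clean reading on it. The expectation for a 1.4-fold higher number from compound 3 to compound 4 (0.14 log units; within the scatter) is therefore no change beyond the scatter, with the range widened on both sides for want of a reference step. On that basis compound 4 is estimated at 25 nM in this assay, between 6 nM and 100 nM.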

Compound 4, half-maximal inhibitory concentration: 28 nM
For compound 4 the middle estimate is 1.1-fold (0.05 log units) below the measured one, within the range that was stated.
By their numbers in this assay, from the lowest: compounds 3 and 4 (each within the scatter of the next); then compound 2; then compound 1.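

Among the compounds shown here, the step at this position reads a 1.6-fold higher number from compound 3 to compound 4 (0.19 log units; within the scatter) in this assay, the first clean reading here, as compounds 1 and 2 differ from compound 3 in more than one place. On this single pair, a six-membered aromatic ring of carbon can replace ethyl on a saturated chain carbon bound to an aromatic nitrogen with no change beyond the scatter, a reading that applies only alongside the other groups shared by compounds 3 and 4. Nothing on hand gives a reason for this result.

The compounds shown leave open how an amine, a carboxylic acid or a longer chain in place of the phenyl would read at this carbon. Also open, on these data alone, is whether phenyl in place of ethyl reads the same when compound 3's other groups are changed.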